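Adding a side chain to a short-lived compound

The source may report more compounds than this note shows. Statements on the series, on what has been measured and on what is new or still open speak of the compounds shown alone.

Measured in an ADME assay on microsomes from liver (Rattus norvegicus) for metabolic stability; on this read-out higher numbers stand for a longer-lived compound and lower numbers for a shorter-lived compound:
- compound 1 `CC#C[C@@H](Cc1nnn[nH]1)c1ccc(OCc2ccc3sc(F)c(-c4ccccc4C)c3c2)cc1`: 0.367 h
- compound 2 `CC#C[C@@H](Cc1nnn[nH]1)c1ccc(OCc2cc(Cl)c3scc(-c4ccccc4C)c3c2)cc1`: 0.117 h

Of these two compounds, compound 1 has the higher number in this assay. The gap between the two numbers lies beyond the usual scatter of repeated measurements. The next compound to be tested, compound 3 `CC#C[C@@H](Cc1nnn[nH]1)c1ccc(OCc2ccc3sc(F)c(-c4ccc(OCCOC)cc4C)c3c2)cc1`, keeps the core of compound 1 and changes it in one place: 2-methoxyethoxy in place of hydrogen on an aromatic carbon. Here, 2-methoxyethoxy takes the place of hydrogen on an aromatic carbon, meta to a methyl group and para to a large group.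

Among the compounds with values here, the two measured compounds differ from each other in more than one place, so no measured step shows what this change does. Any forecast therefore rests on thin evidence. In this assay, a small downward step is expected, one that may well stay within the scatter. The estimated change is a 1.5-fold lower number from compound 1 to compound 3 (0.17 log units; within the scatter). The expected value for compound 3 is 0.25 h, with an estimated range from 0.09 h to 0.65 h.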

Compound 3, half-life: 0.35 h
Estimate against measurement, compound 3: 1.4-fold (0.15 log units) below; low and high end bracket the measured number.
By their numbers in this assay, from the lowest: compound 2; then compounds 3 and 1 (each within the scatter of the next).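

In this assay, putting a 2-methoxyethoxy chain on the aromatic carbon meta to a methyl group and para to a large group gives a 1.0-fold lower number from compound 1 to compound 3 (0.02 log units; within the scatter), so the two compounds cannot be told apart on this read-out. Within the data shown here, the earlier pair differed in more than one place, so this is the first reading of a single change at this position: a chain of 5 heavy atoms, with no ring, enters here and no step beyond the usual scatter appears. No measurement shown here speaks to the reason for this result.

The compounds shown leave open whether this holds only for the 2-methoxyethoxy chain or also for other groups on the same carbon, such as a shorter methoxy group, a longer chain ending in an amine, or a carboxylic acid. Among these compounds, they also leave open whether the same chain would give a similar step on the core of compound 2, the compound with the lowest number so far.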